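Ethyl(arylmethyl)amino versus bis(dimethylaminoethyl)amino on the benzamide

A few compounds are considered here, and "the series" means these few. Any claim that something is new, unique, unknown or untested is made for them only; others in the source may bear on it.

Measured so far:
compound 1 `CCN(Cc1ccccn1)c1ccc(C(=O)N2CCc3ccc(OS(N)(=O)=O)cc3C2)cc1` — 87.7%
compound 2 `CN(C)CCN(CCN(C)C)c1ccc(C(=O)N2CCc3ccc(OS(N)(=O)=O)cc3C2)cc1` — 15.9%
compound 3 `NS(=O)(=O)Oc1ccc2c(c1)CN(C(=O)c1cccc(N(Cc3ccccc3)Cc3ccco3)c1)CC2` — 90.5%

In an assay on HEK293 cells for inhibition of Steryl-sulfatase (Homo sapiens), tested at 1 uM (on this read-out lower numbers stand for a weaker effect and higher numbers for a stronger effect at the one concentration tested), compound 2 stands lowest of the three numbers. Its nearest neighbour is compound 1, and the gap a number 71.8 percentage points lower from compound 1 to compound 2 (beyond the scatter) lies beyond the scatter; compound 2 gives 15.9%, while compound 3, the furthest, gives 90.5%, also beyond the scatter.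

The unmeasured compound 4 `CCN(Cc1ccc(Br)cc1)c1ccc(C(=O)N2CCc3ccc(OS(N)(=O)=O)cc3C2)cc1` differs from compound 2 in one place: (4-bromobenzyl)(ethyl)amino in place of bis(2-(dimethylamino)ethyl)amino on an aromatic carbon. The bis(2-(dimethylamino)ethyl)amino leaves and a (4-bromobenzyl)(ethyl)amino enters on the aromatic carbon.

For the measured compounds named here, only one measured step bears on this change, the one from compound 1 to compound 2, a number 71.8 percentage points lower from compound 1 to compound 2 (beyond the scatter), which is large. Compound 4 runs that step backwards in kind: an ethyl(arylmethyl)amino returns in place of the bis(2-(dimethylamino)ethyl)amino, with a 4-bromobenzyl rather than a (pyridin-2-yl)methyl on the nitrogen. Compound 3, which also carries a benzyl on its amino nitrogen, gives 90.5%, in the same region as compound 1.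

A large upward step is therefore expected, a number 69.1 percentage points higher from compound 2 to compound 4 (beyond the scatter), bringing compound 4 back to the level of compound 1 and compound 3. The estimate for compound 4 in this assay is 85%, in the range 70% to 95%.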

Compound 4, a percentage reported as inhibition, at one concentration (the size of the read-out at that concentration, not a potency): 95.9%
For compound 4 the middle estimate is 10.9 percentage points below the measured one, and the stated range ends below it.
By their numbers in this assay, from the lowest: compound 2; then compounds 1, 3 and 4 (each within the scatter of the next).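

In this assay, a number 80 percentage points higher from compound 2 to compound 4 (beyond the scatter), so a second ethyl(arylmethyl)amino group on the aromatic carbon, para to a large group, stands clear of the bis(2-(dimethylamino)ethyl)amino compound. The entering group has a six-membered aromatic ring of carbon only, which shows that a ring nitrogen in the arylmethyl group is not required for a high read-out at this position. The exchange of pyridin-2-yl for 4-bromophenyl gives a number 8.2 percentage points higher from compound 1 to compound 4 (within the scatter), so this assay does not separate the two aryl groups, and no evidence is available to explain either step.

Going by these compounds, the exchange from compound 2 to compound 4 replaces both nitrogen substituents at once, so it remains open whether one 2-(dimethylamino)ethyl chain beside the ethyl group would lower the read-out or whether the bis(2-(dimethylamino)ethyl)amino arrangement is needed. On these data alone, how far the arylmethyl group tolerates change also remains open, for instance a 4-carboxybenzyl or 4-(aminomethyl)benzyl group in place of the 4-bromobenzyl, and a read-out at one concentration gives no potency for compound 1 or compound 4.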